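Capping a phenol: the step from compound 1 to compound 4

A few compounds are considered here, and "the series" means these few. Any claim that something is new, unique, unknown or untested is made for them only; others in the source may bear on it.

compound 1, `COc1cc(/C=C/C(=O)c2cccc(O)c2)ccc1O`: 63.8%
compound 2, `COc1cccc(/C=C/C(=O)c2cccc(O)c2)c1OC`: 57.8%
compound 3, `COc1cccc(CCCc2cccc(O)c2)c1OC`: 96.1%

In an ADME assay on RAW264.7 cells (Mus musculus) for cytotoxicity, read by MTT assay, with a stated time of 24 h, tested at 5 ug/mL (a higher number here means a weaker effect of the compound at the concentration tested, a lower number a stronger effect), compound 1 stands second highest of the three numbers. Its nearest neighbour is compound 2, a little lower but within the usual scatter; compound 3 lies far above it, beyond the scatter. The next compound, compound 4 with structure `COc1ccc(/C=C/C(=O)c2cccc(O)c2)cc1OC`, differs from compound 1 by methyl in place of hydrogen on an oxygen on an aromatic ring. Among the compounds with values here, no pair of measured compounds shows this change on its own. Compound 2, which also carries two methoxy groups and no free hydroxy on that ring, sits within the scatter of compound 1, so the step of a number 3.8 percentage points lower from compound 1 to compound 4 (within the scatter) is expected to be small, with no direction beyond the scatter. Compound 4 is therefore estimated at 60%, within a range from 45% to 78%.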

Compound 4, a percentage reported as activity, at one concentration (the size of the read-out at that concentration, not a potency): 83.8%
Beside the measured number, compound 4's estimate is 23.8 percentage points below it, outside the stated range (above it).
By their numbers in this assay, from the lowest: compounds 2 and 1 (each within the scatter of the next); then compound 4; then compound 3.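

In this assay, the change from hydroxy to methoxy on the aromatic ring gives a number 20 percentage points higher from compound 1 to compound 4 (beyond the scatter). This is the first change in a single place among these compounds, and it shows that adding a methyl to this oxygen does matter here: the effect at the concentration tested is weaker. Nothing available explains this step. As far as these compounds go, whether a larger ethoxy group on the same oxygen, or an amine in place of the hydroxy, would move the number in the same direction remains open.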